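This account rests on a few compounds, and the source may have more. Where it says the series, first, only, none or still open, it means among the compounds named here.

Measured so far in a functional assay on A2780 cells (Homo sapiens) for cytotoxicity, read by MTT assay, with a stated time of 48 h (on this read-out higher numbers stand for weaker inhibition and lower numbers for stronger inhibition), on these compounds:
- compound 1 `CCn1cc(-c2nc3ccccc3[nH]2)c(=O)c2cc(F)c(N3CCNCC3)nc21` gives 4800 nM
- compound 2 `CCn1cc(-c2nc3ccccc3o2)c(=O)c2cc(F)c(N3CCNC(C)C3)c(F)c21` gives 83500 nM

Compound 1 holds the lower of these two numbers, and the gap up to compound 2 lies beyond the usual scatter. These two compounds differ in more than one place, so that gap cannot be tied to any single change.

Compound 3 `CCn1cc(-c2nc3ccccc3s2)c(=O)c2cc(F)c(N3CCNCC3)nc21` keeps the core of compound 1 and changes one group on an aromatic carbon of a six-membered aromatic ring with 1 nitrogen: 1,3-benzothiazol-2-yl in place of 1H-benzimidazol-2-yl on an aromatic carbon is the whole difference. For the measured compounds named here, no measured pair isolates this swap. Going by the values given here, the only hint is compound 2 at 83500 nM without the 1H-benzimidazol-2-yl group, which points weakly towards a higher number. The expected change is a 1.5-fold higher number from compound 1 to compound 3 (0.16 log units; within the scatter) and is a modest one towards weaker inhibition, possibly no larger than the scatter. For compound 3 the estimate is 7000 nM within an expected range of 1500 nM to 35000 nM in this assay on this uncertain basis.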

Compound 3, half-maximal inhibitory concentration: 2700 nM
Compound 3: middle estimate off by 2.6-fold (0.41 log units), on the high side, within the range that was stated.
By their numbers in this assay, from the lowest: compounds 3 and 1 (each within the scatter of the next); then compound 2.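

In this assay, putting 1,3-benzothiazol-2-yl in place of 1H-benzimidazol-2-yl on this aromatic carbon gives a 1.8-fold lower number from compound 1 to compound 3 (0.25 log units; within the scatter), so the two groups cannot be told apart by this read-out. For the compounds shown here, this is the first direct look at this position, since compound 1 and compound 2 differ in more than one place. The group that leaves carries a hydrogen-bond donor and the group that enters carries none, yet on the core of compound 1 this swap stays within the scatter, and nothing available explains why the two read alike.

As far as these compounds go, both groups are fused pairs of rings of equal heavy-atom count, so it remains open whether a much smaller group on this carbon, such as a carboxylic acid or a nitrile, would read the same. From the compounds shown here alone, the same swap on another core also remains untested by these compounds, since compound 2 cannot be compared directly with either.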